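The compounds below may be only part of what the source reports. "The series", "measured", "known", "first", "only" and "open" are said of these compounds alone.

Working notes on the series, cytotoxicity read-out.

Compound 1 `Fc1cccc(F)c1Cc1cnc(Nc2ccc(Oc3ccncc3)c(Cl)c2)o1` and compound 2 `Fc1cccc(F)c1Cc1cnc(Nc2ccc(Oc3ccncc3)cc2)o1` differ in a single place, hydrogen in place of chloro on an aromatic carbon. In an ADME assay on MT2 cells (Homo sapiens) for cytotoxicity, read by MTT assay (on this read-out higher numbers stand for lower toxicity in this test and lower numbers for higher toxicity in this test), compound 1 gives 21000 nM and compound 2 gives 21000 nM, so no change at the digits printed from compound 1 to compound 2 (within the scatter). Compound 3 `Clc1cccc(Cl)c1Cc1nnc(Nc2ccc(COCc3ccco3)cc2)o1` differs from compound 2 in more than one place, and in this assay compound 3 gives 12000 nM. Compound 2 therefore stands level with compound 1 at the digits shown, and the number for compound 3 is the furthest from it of the three while still lying within the scatter.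

Compound 4 `CSCc1ccc(Nc2ncc(Cc3c(F)cccc3F)o2)cc1` is the next member, with (methylsulfanyl)methyl in place of (pyridin-4-yl)oxy on an aromatic carbon. Within the data shown here, no measured step tests this change. Among the measured compounds shown here, the one single-point step available, from compound 1 to compound 2, concerns a different group at a different place and gave no change, and compound 3 is separated from compound 2 by several changes at once. The step of no change at the digits printed from compound 2 to compound 4 (within the scatter) is expected to be none beyond the scatter, in no particular direction, and the range is set wide. Compound 4 is expected to give 21000 nM in this assay, estimated to fall between 8000 nM and 55000 nM.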

Compound 4, half-maximal cytotoxic concentration: > 100000 nM
Compound 4 was reported as a limit (the forecaster's own chance of this, stated with the estimate: 15%); at least 4.7-fold (0.67 log units) between middle value and limit.
By their numbers in this assay, from the lowest: compounds 3, 1 and 2 (each within the scatter of the next). At a limit, above all of these: compound 4.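

Among these compounds, replacing (pyridin-4-yl)oxy with (methylsulfanyl)methyl, on an aromatic carbon para to a large group, gives an at least 4.7-fold higher number from compound 2 to compound 4 (0.67 log units; beyond the scatter), whereas the one earlier single-place change, at the chloro group, gave no change at the digits printed from compound 1 to compound 2 (within the scatter). This is therefore the first change in the series shown to move the read-out beyond the scatter, and it moves towards lower toxicity in this test. In this assay compound 4 gives > 100000 nM, which is a limit of the assay and not a number, so the step has a lower bound only and its full size cannot be stated: the limit of > 100000 nM in this assay, at which 1 of the 4 values shown sits.

With a single replacement at this place, the part played by the sulfur, by the absence of a ring or by the smaller group as a whole cannot be separated, and no cause can be assigned to any of them. From the compounds shown here alone, whether an amine or a longer chain ending in a carboxylic acid at the same place would read like compound 2 or like compound 4 stays open.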